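Swapping a Fluorophenyl for a Hydroxyphenyl on Two Cores

A few compounds are considered here, and "the series" means these few. Any claim that something is new, unique, unknown or untested is made for them only; others in the source may bear on it.

Measured so far:
Compound 1, `O=C1OC[C@H](Cc2ccccc2)[C@H]1Cc1cccc(F)c1`: 75000 nM
Compound 2, `O=C1OC[C@H](Cc2ccccc2)[C@H]1Cc1ccc(O)cc1`: 88000 nM
Compound 3, `Fc1cccc(C[C@H]2COC[C@@H]2Cc2ccc(Cl)c(Cl)c2)c1`: 20000 nM

In a functional assay on HL-60 cells (Homo sapiens) for cytotoxicity, read by WST assay, with a stated time of 48 h (on this read-out higher numbers stand for an effect only at larger amounts of compound and lower numbers for an effect already at smaller amounts), compound 1 gives 75000 nM, and compound 2 gives 88000 nM. Compound 2 differs from compound 1 by 4-hydroxyphenyl in place of 3-fluorophenyl on a saturated chain carbon bound to a saturated ring carbon, and this gave a 1.2-fold higher number from compound 1 to compound 2 (0.07 log units; within the scatter). Compound 3 rests on a different core; the difference between the two cores is not broken down here. In this assay compound 3 gives 20000 nM, the lowest of the three numbers and beyond the scatter from compound 1 and from compound 2. Compound 4, `Oc1ccc(C[C@H]2COC[C@@H]2Cc2ccc(Cl)c(Cl)c2)cc1`, has not yet been measured; it carries the same change as before: 4-hydroxyphenyl in place of 3-fluorophenyl on a saturated chain carbon bound to a saturated ring carbon. Because the same change gave a 1.2-fold higher number from compound 1 to compound 2 (0.07 log units; within the scatter), the step from compound 3 to compound 4 is expected to be small, a 1.2-fold higher number from compound 3 to compound 4 (0.08 log units; within the scatter). Compound 4 is therefore estimated at 24000 nM, likely between 10000 nM and 60000 nM.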

Compound 4, half-maximal effective concentration: 31000 nM
The estimate for compound 4 lay 1.3-fold (0.11 log units) below the measured number; the measured number falls inside the stated range.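

In this assay, putting 4-hydroxyphenyl in place of 3-fluorophenyl gave a 1.6-fold higher number from compound 3 to compound 4 (0.19 log units; within the scatter). Set beside the earlier step, the change carried from one core to the other with no difference beyond the usual scatter: the same change on two cores in this assay, a 1.2-fold higher number (0.07 log units; within the scatter) from compound 1 to compound 2 and a 1.6-fold higher number (0.19 log units; within the scatter) from compound 3 to compound 4, 1.3-fold (0.12 log units) apart, within the scatter of two such steps. On these two cores, then, the swap leaves the number about where it was, but neither step is large enough to show a real effect of the change, and two cores say nothing certain about a third.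

The compounds shown leave open whether a different group at this place, such as an amine or a carboxylic acid, would shift the number beyond the scatter.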